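A few compounds are considered here, and "the series" means these few. Any claim that something is new, unique, unknown or untested is made for them only; others in the source may bear on it.

Measured in a functional assay on RT-112 cells (Homo sapiens) for antiproliferative activity, read by MTT assay, with a stated time of 72 h; a higher number here means a weaker inhibitor of growth, a lower number a stronger inhibitor of growth:
- compound 1 `COc1cc(Nc2ncnc3c(NC(=O)Nc4cc(Cl)c(Cl)cc4Cl)cccc23)cc(OC)c1`: 4890 nM
- compound 2 `COc1cc(Nc2ncnc3c(NC(=O)Nc4ccc5c(c4)OCCO5)cccc23)cc(OC)c1`: 2750 nM
- compound 3 `COc1cc(Nc2ncnc3c(NC(=O)Nc4ccc(Cl)cc4)cccc23)cc(OC)c1`: 2490 nM

Compound 3, at 2490 nM, cannot be separated from the other two compounds, since every measured step stays within the scatter. Compound 4 `COc1cc(Nc2ncnc3c(NC(=O)Nc4ccc(F)cc4F)cccc23)cc(OC)c1` keeps the shared core and carries 2,4-difluorophenyl in place of 4-chlorophenyl on an amide-type nitrogen.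

For the measured compounds named here, all the measured steps change the group at this same place. The nearest in kind is a 2.0-fold lower number from compound 1 to compound 3 (0.29 log units; within the scatter), where 4-chlorophenyl replaces 2,4,5-trichlorophenyl. The replacement of 2,3-dihydro-1,4-benzodioxin-6-yl by 4-chlorophenyl gives a 1.1-fold lower number from compound 2 to compound 3 (0.04 log units; within the scatter), and the remaining step is a 1.8-fold lower number from compound 1 to compound 2 (0.25 log units; within the scatter). None of the three leaves the scatter, so the groups tried here have not yet separated in this assay. Going by the values given here, no measured compound carries a fluorine on this ring, so the expectation is an extrapolation and the range is kept wide. No step beyond the scatter is expected, and no direction can be argued from these data. The expected step is a 1.1-fold higher number from compound 3 to compound 4 (0.05 log units; within the scatter). For compound 4 the estimated value is 2800 nM, with an expected range of 1300 nM to 6000 nM.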

Compound 4, concentration for 50% growth inhibition: 2460 nM
Compound 4: the middle estimate sits 1.1-fold (0.06 log units) above what was measured, within the range that was stated.
By their numbers in this assay, from the lowest: compounds 4, 3, 2 and 1 (each within the scatter of the next).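

In this assay, a fluorine-bearing group on the amide-type nitrogen cannot be told apart from 4-chlorophenyl (a 1.0-fold lower number from compound 3 to compound 4 (0.01 log units; within the scatter)) or from 2,3-dihydro-1,4-benzodioxin-6-yl (a 1.1-fold lower number from compound 2 to compound 4 (0.05 log units; within the scatter)). The largest step in the set so far (a 2.0-fold lower number from compound 1 to compound 4 (0.30 log units; within the scatter)) also stays within the scatter, so replacing 2,4,5-trichlorophenyl with 2,4-difluorophenyl does not separate the two compounds, and this position has now taken chlorine-bearing, fluorine-bearing and benzodioxinyl groups with no resolved difference in this assay. No supporting data are available to explain why these four groups read alike.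

Going by these compounds, all four compounds carry an aromatic group at this place, so it remains open whether a cyclohexyl group, a longer alkyl chain, or a phenyl ring bearing a dimethylamino group or a carboxylic acid would give a step beyond the scatter. The rest of the structure is the same in all four compounds, so these results also leave open how changes elsewhere on the shared core would read in this assay and whether any such change would make this position matter more.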